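The compounds below may be only part of what the source reports. "The series", "measured", "known", "first", "only" and "open" are said of these compounds alone.

Compound 1 `CCN(CC)C(=O)c1ccc(NC(=O)C(C)(O)C(F)(F)F)cc1` — > 30000 nM
Compound 2 `CC(O)(C(=O)Nc1ccc(Sc2ccccc2)cc1)C(F)(F)F` — > 30000 nM

In an assay on a protein complex (Cavia porcellus) with sulfonylurea receptors; K-ATP channels (Homo sapiens) as the target (on this read-out lower numbers stand for stronger inhibition and higher numbers for weaker inhibition), compound 2 gives > 30000 nM, which is a limit of the assay and not a number. In this assay compound 1 likewise gives > 30000 nM, again a limit. The only measured step, a step that the two limits leave unreadable from compound 1 to compound 2, cannot be read in size, because the limit of > 30000 nM in this assay, at which 2 of the 2 values shown sit, is where both shown values sit. Compound 3 `CN(C)S(=O)(=O)c1ccc(NC(=O)C(C)(O)C(F)(F)F)cc1` differs from compound 2 in one place: dimethylsulfamoyl in place of phenylsulfanyl on an aromatic carbon. No measured step tells how this exchange acts, and the two shown values give no direction to lean on. Both measured compounds carry a group at this place and sit at the limit, so compound 3 is expected to do the same. The expected step that the limit leaves unreadable from compound 2 to compound 3 amounts to nothing beyond the scatter. Compound 3 is estimated at 40000 nM, within a range from 15000 nM to 150000 nM.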

Compound 3, half-maximal inhibitory concentration: 480 nM
Compound 3: the middle estimate sits 83-fold (1.92 log units) above what was measured; the measured number lies below the stated range.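

At this place, para to a large group, the choice of group turns out to matter a great deal: in this assay, with the rest of the molecule unchanged, dimethylsulfamoyl gives an at least 62-fold lower number from compound 2 to compound 3 (1.79 log units; beyond the scatter), and set against diethylcarbamoyl it gives an at least 62-fold lower number from compound 1 to compound 3 (1.79 log units; beyond the scatter). Of the three groups shown, only dimethylsulfamoyl gives a real number, and the true size of both steps could be larger than printed. The step between the other two compounds still cannot be read, and both remain at the same limit: the limit of > 30000 nM in this assay, at which 2 of the 3 values shown sit.

The compounds shown leave open which part of dimethylsulfamoyl matters, the sulfonyl unit or the two methyl groups on its nitrogen. A methylsulfonyl group or an unsubstituted sulfonamide at this place would separate the two.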